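A few compounds are considered here, and "the series" means these few. Any claim that something is new, unique, unknown or untested is made for them only; others in the source may bear on it.

Measured so far:
compound 1, `CN(C)CCCC1(c2ccc(F)cc2)OCc2cc(-c3cccc(C#N)c3)ccc21`, in an assay on Caudate-putamen for displacement of a labelled ligand from sodium-dependent dopamine transporter (Rattus norvegicus), read by scintillation counting (on this read-out higher numbers stand for weaker inhibition and lower numbers for stronger inhibition), gives 737 nM.
compound 2, `CN(C)CCCC1(c2ccc(F)cc2)OCc2cc(CCc3ccccc3)ccc21`, in this assay gives "not determined" (no result reported), so it has no reported number in this assay.

Compound 2 therefore stands nowhere on the numbers shown; its only neighbour with a value is compound 1, which carries a different substituent at the same position of the shared core. Compound 3, `CN(C)CCCC1(c2ccc(F)cc2)OCc2cc(I)ccc21`, differs from compound 2 by iodo in place of phenethyl on an aromatic carbon. Within the data shown here, with no measured pair to anchor this change, no size or direction for the step can be read off, and any expectation rests on compound 1 alone. Compound 3 is estimated at 500 nM in this assay, with a likely range from 100 nM to 3000 nM.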

Compound 3, inhibition constant: 1350 nM
Estimate against measurement, compound 3: 2.7-fold (0.43 log units) below; the range from low to high includes it.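

In this assay, iodo in place of 3-cyanophenyl on this aromatic carbon gives a 1.8-fold higher number from compound 1 to compound 3 (0.26 log units; within the scatter), so these two groups cannot be told apart on this read-out. This position thus accepts a single iodine atom or a whole substituted aromatic ring with no clear difference in the number. Nothing available explains this result. Compound 2 has no number, so its steps cannot be read. As far as these compounds go, how an amine or a carboxylic acid at this position would read also remains open.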